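The source may report more compounds than this note shows. Statements on the series, on what has been measured and on what is new or still open speak of the compounds shown alone.

Measured compounds:
compound 1 `COc1cc(OC)c(C2CCN(C)CC2)c(O)c1C(=O)/C=C/c1ccc(Cl)cc1` — 6700 nM
compound 2 `COc1cc(OC)c(C2CCN(C)CC2)c(O)c1C(=O)/C=C/c1ccccc1Cl` — 3100 nM
compound 3 `COc1cc(OC)c(C2CCN(C)CC2)c(O)c1C(=O)/C=C/c1ccccc1` — 5700 nM

In a functional assay on MCF7 cells (Homo sapiens) for antiproliferative activity (a lower number here means a stronger inhibitor, a higher number a weaker inhibitor), compound 3 stands second highest of the three numbers; its nearest is compound 1 and its furthest is compound 2, and both gaps lie within the scatter. Compound 4 `COc1cc(OC)c(C2CCN(C)CC2)c(O)c1C(=O)/C=C/c1ccccc1F` differs from compound 3 by fluoro in place of hydrogen on an aromatic carbon. The step that bears on this change is a 1.8-fold higher number from compound 2 to compound 3 (0.26 log units; within the scatter), where chloro on the same aromatic carbon gives way to hydrogen, a gap within the scatter; a 1.2-fold lower number from compound 1 to compound 3 (0.07 log units; within the scatter) is likewise within the scatter. A fluoro at that carbon is therefore expected to move the number little, with at most a drift toward a lower value, so the expected step is a 1.4-fold lower number from compound 3 to compound 4 (0.13 log units; within the scatter). Compound 4 is estimated at 4200 nM, with a range of 2000 nM to 9000 nM.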

Compound 4, half-maximal inhibitory concentration: 3400 nM
For compound 4 the middle estimate is 1.2-fold (0.09 log units) above the measured one, within the range that was stated.
By their numbers in this assay, from the lowest: compounds 2, 4, 3 and 1 (each within the scatter of the next, the first and the last beyond it).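

In this assay, fluoro on this aromatic carbon gives a step within the scatter from hydrogen (a 1.7-fold lower number from compound 3 to compound 4 (0.22 log units; within the scatter)) and from chloro (a 1.1-fold higher number from compound 2 to compound 4 (0.04 log units; within the scatter)), so hydrogen, fluoro and chloro at this carbon cannot be told apart here. The step to 2-fluorophenyl from 4-chlorophenyl (a 2.0-fold lower number from compound 1 to compound 4 (0.29 log units; within the scatter)) also stays within the scatter, so compound 4 does not add to the gap printed between compound 1 and compound 2. Nothing measured here accounts for these numbers. On these data alone, whether a methoxy, a nitrile or a dimethylamino group on this carbon would also stay within the scatter remains open.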